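A Fluorine Added to the Core of Compound 1

A few compounds are considered here, and "the series" means these few. Any claim that something is new, unique, unknown or untested is made for them only; others in the source may bear on it.

Compound 1 `COc1cccc(-c2cc(C(=O)Nc3ccc(Oc4ccnc5cc(OCCCN6CCCCC6)c(OC)cc45)c(F)c3)c3ccccc3n2)c1` gives 1740 nM in a functional assay on HT-29 cells (Homo sapiens) for cytotoxicity, read by MTT assay, with a stated time of 72 h; on this read-out higher numbers stand for weaker inhibition and lower numbers for stronger inhibition. Compound 2 `COc1cc2c(Oc3ccc(NC(=O)c4cc(-c5cccc(Cl)c5)nc5ccccc45)cc3F)ccnc2cc1OCCCN1CCCCC1` gives 62 nM in this assay.

Among the measured compounds shown here, compound 1 stands highest of the two numbers; its only neighbour is reached by a 28-fold lower number from compound 1 to compound 2 (1.45 log units; beyond the scatter), a change on the pendant ring. Compound 3 `COc1cccc(-c2cc(C(=O)Nc3ccc(Oc4ccnc5cc(OCCCN6CCCCC6)c(OC)cc45)c(F)c3)c3cc(F)ccc3n2)c1` differs from compound 1 by fluoro in place of hydrogen on an aromatic carbon, a change on the core instead. For the measured compounds named here, no measured step touches the core, so the one known step gives no guidance for this change. Compound 3 is therefore expected to stay close to compound 1, with a 1.3-fold lower number from compound 1 to compound 3 (0.13 log units; within the scatter) inside the usual scatter, at an estimated 1300 nM (range 400 nM to 4500 nM).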

Compound 3, half-maximal inhibitory concentration: 2500 nM
Beside the measured number, compound 3's estimate is 1.9-fold (0.28 log units) below it, within the range that was stated.
By their numbers in this assay, from the lowest: compound 2; then compounds 1 and 3 (each within the scatter of the next).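

In this assay, among the compounds shown here, the step of a 1.4-fold higher number from compound 1 to compound 3 (0.16 log units; within the scatter) is the first one measured on the shared core. It shows that fluoro in place of hydrogen at this carbon of the core leaves compound 3 within the scatter of compound 1, whereas the change on the pendant ring gave a 28-fold lower number from compound 1 to compound 2 (1.45 log units; beyond the scatter) and so moved the number well beyond it. No measurement at hand offers an explanation for this result.

On these data alone, it remains open whether an amine or a carboxylic acid on this same carbon would also stay within the scatter of compound 1. As far as these compounds go, it also remains open whether fluoro here would behave the same way alongside the chloro of compound 2.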